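A group swap on compound 1 at the limit

The compounds below may be only part of what the source reports. "The series", "measured", "known", "first", "only" and "open" are said of these compounds alone.

In a physicochemical assay for solubility, using the shake flask method, in phosphate buffer, measured as kinetic solubility, with a stated time of 20 h, at pH 6.5 (on this read-out lower numbers stand for lower solubility and higher numbers for higher solubility), compound 1 `COc1cccnc1Nc1cc2[nH]c(-c3cccc(C(F)(F)F)c3)nc2cn1` gives < 5000 nM, which is a limit and not a number. Compound 2 `Fc1ccc(-c2nc3cnc(Nc4ccccn4)cc3[nH]2)cc1C(F)(F)F` gives < 5000 nM, also a limit. Compound 3 `Fc1ccc(-c2nc3cnc(Nc4ccccn4)cc3[nH]2)cc1F` gives < 5000 nM, again a limit. The whole picture so far is the limit of < 5000 nM in this assay, at which 3 of the 3 values shown sit. Among the compounds with values here, the one measured step, a step that the two limits leave unreadable from compound 2 to compound 3, has no readable size and concerns fluoro in place of trifluoromethyl, not the group changed here. Compound 4 `Fc1cnc(Nc2cc3[nH]c(-c4cccc(C(F)(F)F)c4)nc3cn2)c(F)c1` differs from compound 1 as follows: 3,5-difluoropyridin-2-yl in place of 3-methoxypyridin-2-yl on a nitrogen on an aromatic ring. With no readable step to guide it, the expected change, a step that the limit leaves unreadable from compound 1 to compound 4, is none beyond the usual scatter, in neither direction. For compound 4 the estimated value is 3000 nM, with an expected range from 1000 nM to 5000 nM.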

Compound 4, solubility: < 5000 nM
Compound 4: a limit, no number; the forecaster's own chance of this, stated with the estimate: 85%; the middle value lies beyond the limit too.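

The step from compound 1 to compound 4 cannot be read, because both give only a limit and not a number: the limit of < 5000 nM in this assay, at which 4 of the 4 values shown sit.

The compounds shown leave open how far each value lies past that limit, and so whether 3,5-difluoropyridin-2-yl in place of 3-methoxypyridin-2-yl changes the read-out at all.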